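A few compounds are considered here, and "the series" means these few. Any claim that something is new, unique, unknown or untested is made for them only; others in the source may bear on it.

Compound 2, `CCN(CC)CN1C(=O)/C(=N/NC(=S)Nc2ccc(OC)cc2)c2ccccc21`, was tested in an ADME assay on Vero cells (Chlorocebus sabaeus) for cytotoxicity (a higher number here means that more compound is tolerated, a lower number that less compound is tolerated), and gave 4000 nM. Among the compounds with values here, that is the lower of the two values measured so far. Compound 1, `CCN(CC)CN1C(=O)/C(=N/NC(=S)Nc2ccccc2)c2cc(Cl)ccc21`, gives 100000 nM in this assay, a value that lies beyond the scatter from compound 2; the two structures differ in more than one place, so no single change can be tied to that gap.

Compound 3, `CCN(CC)CN1C(=O)/C(=N/NC(=S)Nc2ccc(OC)cc2)c2cc(Cl)ccc21`, is the next compound. It differs from compound 2 by one change: chloro in place of hydrogen on an aromatic carbon. Within the data shown here, no step between measured compounds isolates this change, so its size in this assay is uncertain. Because compound 1, which carries the chloro, gives 100000 nM, a rise in tolerated concentration is expected, moderate in size. The expected step from compound 2 to compound 3 is a 3.8-fold higher number from compound 2 to compound 3 (0.57 log units; beyond the scatter). Compound 3 is therefore estimated at 15000 nM, within a range from 4000 nM to 60000 nM.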

Compound 3, minimum cytotoxic concentration: 4000 nM
For compound 3 the middle estimate is 3.8-fold (0.57 log units) above the measured one; the measured number falls inside the stated range.
By their numbers in this assay, from the lowest: compounds 2 and 3 (each within the scatter of the next); then compound 1.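

In this assay, adding chloro to the fused ring system while the methoxy group stays in place has no visible effect, with no change at the digits printed from compound 2 to compound 3 (within the scatter). With the chloro held constant, adding methoxy on an aromatic carbon gives a large step, a 25-fold lower number from compound 1 to compound 3 (1.40 log units; beyond the scatter), so among these three compounds the lower tolerated concentration goes with the methoxy group and not with the chloro. Nothing measured here explains this result.

From the compounds shown here alone, it remains open whether an amine, a carboxylic acid or a longer chain such as ethoxy in place of the methoxy would give a similarly low number. Going by these compounds, it is also open whether chloro would still make no difference with one of those groups in that place.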